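This account rests on a few compounds, and the source may have more. Where it says the series, first, only, none or still open, it means among the compounds named here.

Measured so far:
compound 1, `CC1=CC[C@H](C(C)(C)NC(=S)N/N=C/c2ccccc2)CC1`: 84400 nM
compound 2, `CC1=CC[C@H](C(C)(C)NC(=S)N/N=C/c2cccc(Cl)c2)CC1`: 61000 nM

In a functional assay on MCF7 cells (Homo sapiens) for inhibition, read by sulforhodamine B assay, with a stated time of 48 h (on this read-out higher numbers stand for weaker inhibition of growth and lower numbers for stronger inhibition of growth), compound 1 gives 84400 nM, and compound 2 gives 61000 nM. Going by the values given here, compound 2 holds the lower of the two numbers, yet the only step measured, a 1.4-fold lower number from compound 1 to compound 2 (0.14 log units; within the scatter), falls within the scatter, so the two values cannot be ordered against each other.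

Compound 3, `CC1=CC[C@H](C(C)(C)NC(=S)N/N=C/c2cccc([N+](=O)[O-])c2)CC1`, is the next member of the series. It differs from compound 2 by nitro in place of chloro on an aromatic carbon. Among the compounds with values here, no measured step exchanges one substituent for another on that aromatic carbon; the one step that bears on the position at all, a 1.4-fold lower number from compound 1 to compound 2 (0.14 log units; within the scatter), brought in the chloro and made no difference beyond the scatter. The data therefore give no ground for expecting a step beyond the scatter in this assay in either direction.

On that basis compound 3 is estimated at 60000 nM, with a range from 25000 nM to 150000 nM. The step this estimate implies, a 1.0-fold lower number from compound 2 to compound 3 (0.01 log units; within the scatter), is expected to sit within the scatter.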

Compound 3, concentration for total growth inhibition: > 100000 nM
Compound 3 was reported as a limit (the forecaster's own chance of this, stated with the estimate: 10%); middle value at least 1.6-fold (0.22 log units) away from the limit.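

In this assay compound 3 carries a limit of the assay and not a number: the limit of > 100000 nM in this assay, at which 1 of the 3 values shown sits. Read as floors, an at least 1.6-fold higher number from compound 2 to compound 3 (0.21 log units; that floor lies within the scatter) for nitro in place of chloro and an at least 1.1-fold higher number from compound 1 to compound 3 (0.07 log units; that floor lies within the scatter) for nitro in place of hydrogen both lie within the scatter, so neither shows by itself that this aromatic carbon matters, while the true size of each step stays open upward. Going by these compounds alone, what the earlier compounds could not show, and this result does, is that a second group on this carbon, with more heavy atoms than chloro and with hydrogen-bond acceptors, gives no sign of a lower number than the chloro compound and reaches the limit of the read-out.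

On these data alone, how far compound 3 really stands from compound 2 stays open, and with it whether the exchange of chloro for nitro makes a difference beyond the scatter at all. Also open, as far as these compounds go, is whether an amine or a carboxylic acid on the same aromatic carbon would leave the number within the scatter of compound 1 or move it clearly in either direction.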